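A few compounds are considered here, and "the series" means these few. Any claim that something is new, unique, unknown or untested is made for them only; others in the source may bear on it.

Measured compounds so far:

Compound 1 `Cc1ccc2c(c1)C1(C(=O)N2Cc2ccccc2)C(C#N)=C(N)Oc2cc3oc(-c4ccccc4)cc(=O)c3c(O)c21` gives in a functional assay on K562 cells (Homo sapiens) for antiproliferative activity, read by MTT assay, with a stated time of 48 h (on this read-out higher numbers stand for weaker inhibition and lower numbers for stronger inhibition), only the assay limit > 50000 nM.
Compound 2 `CCN1C(=O)C2(C(C#N)=C(N)Oc3cc4oc(-c5ccccc5)cc(=O)c4c(O)c32)c2cc(C)ccc21` gives in this assay only the assay limit > 50000 nM.
Compound 3 `CC(C)(C)OC(=O)CN1C(=O)C2(C(C#N)=C(N)Oc3cc4oc(-c5ccccc5)cc(=O)c4c(O)c32)c2ccccc21` gives in this assay only the assay limit > 50000 nM.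

Compound 2 therefore stands at the limit of this assay, and it is not alone there: the limit of > 50000 nM in this assay, at which 3 of the 3 values shown sit. No number is known for any compound of the series. Within the data shown here, the only single-point comparison among the measured compounds, from compound 1 to compound 2, reads a step that the two limits leave unreadable from compound 1 to compound 2, so it carries no information on size or direction.

Compound 4 `Cc1ccc2c(c1)C1(C(=O)N2)C(C#N)=C(N)Oc2cc3oc(-c4ccccc4)cc(=O)c3c(O)c21` differs from compound 2 by hydrogen in place of ethyl on an amide-type nitrogen in a ring. No measured step bears on this change: the one step shown is unreadable, and the three values are all limits. The expectation for compound 4 in this assay thus rests on the series itself, where every result so far sits at the limit, rather than on any readable step. Compound 4 is expected to give about 60000 nM, with a range from 20000 nM to 200000 nM, most likely again as a limit. This estimate corresponds to an expected step that the limit leaves unreadable from compound 2 to compound 4, that is, none beyond the scatter.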

Compound 4, half-maximal inhibitory concentration: > 50000 nM
Compound 4: only a limit was reported; the forecaster's own chance of this, stated with the estimate: 80%; the middle value lies beyond the limit too.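

In this assay compound 4 gives > 50000 nM, a limit and not a number. Its steps from compound 1 and compound 2 therefore cannot be read. Still open is whether hydrogen, ethyl or benzyl on the amide-type nitrogen in a ring makes any difference, and whether any compound here would give a number: the limit of > 50000 nM in this assay, at which 4 of the 4 values shown sit.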